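The source may report more compounds than this note shows. Statements on the series, on what has been measured and on what is new or still open speak of the compounds shown alone.

Working notes on the series. Among the measured compounds shown here, in an ADME assay for permeability, using PAMPA, at pH 7.4 (on this read-out lower numbers stand for lower permeability and higher numbers for higher permeability), compound 1 `Cc1cc(NC(=O)Nc2ccccc2OC(F)(F)F)c2ccccc2n1` gives 1110 10^-6 cm/s and stands highest of the two numbers so far. Compound 2 `CC(=O)c1ccc(NC(=O)Nc2cc(C)nc3ccccc23)cc1` gives 473 10^-6 cm/s in the same read-out, a lower number by more than the scatter. Compound 3 `Cc1cc(NC(=O)Nc2ccccc2N)c2ccccc2n1` keeps the core of compound 1 and differs from it in one place, with amino in place of trifluoromethoxy on an aromatic carbon as the whole change. For the measured compounds named here, no measured pair isolates a change of this kind, and the expectation rests on the structural change alone. A fall beyond the scatter is expected in this assay and is estimated as a step (a 3.2-fold lower number from compound 1 to compound 3 (0.50 log units; beyond the scatter)). Compound 3 is expected at about 350 10^-6 cm/s with an estimated range (120 10^-6 cm/s to 800 10^-6 cm/s).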

Compound 3, apparent permeability: 300 10^-6 cm/s
Compound 3: the middle estimate sits 1.2-fold (0.07 log units) above what was measured; the range from low to high includes it.
By their numbers in this assay, from the lowest: compounds 3 and 2 (each within the scatter of the next); then compound 1.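

Among the compounds shown here, at this place, on an aromatic carbon ortho to a large group, amino in place of trifluoromethoxy gives in this assay a 3.7-fold lower number from compound 1 to compound 3 (0.57 log units; beyond the scatter) as the first single-place step, so the read-out does respond to a change here. The step is modest and comes from one pair only, in which the group that enters has a hydrogen-bond donor and fewer heavy atoms than the group that leaves, so these two differences cannot be separated. Nothing in the data bears on what lies behind the step.

Still open, as far as these compounds go, is how a methoxy, a hydroxyl or a fluorine at this same place would compare with amino and trifluoromethoxy. Also open, from the compounds shown here alone, is whether the same change would give a step of similar size with the group moved to another carbon of that ring.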